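A few compounds are considered here, and "the series" means these few. Any claim that something is new, unique, unknown or untested is made for them only; others in the source may bear on it.

In an ADME assay (liver) for metabolic stability, with Liver microsome (Homo sapiens) as the target, read by LC-MS, using microsomes, tested at 1 uM (on this read-out lower numbers stand for a shorter-lived compound and higher numbers for a longer-lived compound), compound 2 `C/C(=N/c1ccnc2cc(Cl)ccc12)NC1CCN(C(C)C)CC1` stands at > 1 h, which is a limit of the assay and not a number. Compound 1 `C/C(=N/c1ccnc2cc(Cl)ccc12)NC1CCN(Cc2ccccc2)CC1` gives > 1 h, which is also a limit. The series thus rests largely on (the limit of > 1 h in this assay, at which 2 of the 3 values shown sit). Only compound 3 `CCN(CC)CCCCN/C(=N\c1ccnc2cc(Cl)ccc12)C(C)C` gives an actual number, 0.917 h. Compound 4 `C/C(=N/c1ccnc2cc(Cl)ccc12)NC1CCN(C)CC1` differs from compound 2 by methyl in place of isopropyl on an amine nitrogen in a ring. Within the data shown here, the one measured step at this ring nitrogen is a step that the two limits leave unreadable from compound 1 to compound 2, so it offers no size to carry over. No shift beyond the scatter is therefore expected in this assay, and the estimated step is a step that the limit leaves unreadable from compound 2 to compound 4. Compound 4 is expected at about 1.5 h, with an estimated range of 0.7 h to 3 h.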

Compound 4, half-life: > 1 h
Compound 4 ended at the assay's limit (the forecaster's own chance of this, stated with the estimate: 60%); the middle value does not contradict the limit.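

In this assay no new step can be read among compound 1, compound 2 and compound 4, all three of which stand at a limit and not at a number. The compounds shown leave open how far these three actually differ from one another in half-life.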